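Compound 2 to compound 3: cyclopentyl leaves

The source may report more compounds than this note shows. Statements on the series, on what has been measured and on what is new or still open speak of the compounds shown alone.

Compound 1 `O=C(Nc1cnc(-n2nccn2)c(Cl)c1)Nc1cncc2ccccc12`: > 20000 nM, a limit
Compound 2 `O=C(Nc1cnc(-n2nccn2)c(Cl)c1)Nc1cnc2ccccc2c1C1CCCC1`: 7020 nM
Compound 3 `CC(O)c1c(NC(=O)Nc2cnc(-n3nccn3)c(Cl)c2)cnc2ccccc12`: not yet measured

All readings come from a functional assay on OCI-Ly3 cells (Homo sapiens) for antiproliferative activity; a lower number here means that less compound is needed, a higher number that more compound is needed for the effect. Compound 1 reaches only a limit, > 20000 nM, and not a number. Compound 2 gives 7020 nM, the only number shown so far in this assay.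

The next step puts 1-hydroxyethyl in place of cyclopentyl on an aromatic carbon, opposite the ring nitrogen: 1-hydroxyethyl in place of cyclopentyl on an aromatic carbon. For the measured compounds named here, no measured step shows what such a swap does. With compound 2 at 7020 nM as the sole numerical anchor, no step beyond the scatter is expected in this assay, and the uncertainty is wide in both directions. The expected change is a 1.4-fold lower number from compound 2 to compound 3 (0.15 log units; within the scatter). For compound 3 the estimated value is 5000 nM, with an expected range of 900 nM to 20000 nM.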

Compound 3, half-maximal effective concentration: 730 nM
Compound 3: middle estimate off by 6.8-fold (0.84 log units), on the high side; measured number below the stated range.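

In this assay, the position opposite the ring nitrogen now has a readable step: a 9.6-fold lower number from compound 2 to compound 3 (0.98 log units; beyond the scatter), with 1-hydroxyethyl in place of cyclopentyl on this aromatic carbon. The read-out therefore responds to the group at this position, and in this one pair the lower number goes with the group that has no ring and carries a hydrogen-bond donor and acceptor. No measurement shown bears on what lies behind the step.

The swap removes the ring and adds the hydroxyl group in one change, so the compounds shown do not separate the two; an ethyl group or a 1-methoxyethyl group on the same carbon would bear on that. Also open, going by these compounds, is how a longer chain such as 3-hydroxypropyl or an amine such as 1-aminoethyl would read in this assay.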